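The source may report more compounds than this note shows. Statements on the series, on what has been measured and on what is new or still open speak of the compounds shown alone.

Measured so far:
- Compound 1 `COc1cc(C(=O)c2cccc3[nH]ccc23)cc(OC)c1OC`: 53.8 nM
- Compound 2 `COc1cc(C(=O)c2ccc3[nH]ccc3c2)cc(OC)c1OC`: 112 nM

In a functional assay on NCI-H460 cells (Homo sapiens) for inhibition, with a stated time of 72 h (on this read-out higher numbers stand for weaker inhibition and lower numbers for stronger inhibition), compound 2 gives 112 nM, the higher of the two numbers. Compound 1 gives 53.8 nM, and the gap between them lies beyond the usual scatter. Compound 3 `COc1cc(C(=O)c2ccc3c(ccn3C(C)C)c2)cc(OC)c1OC` differs from compound 2 by one change, isopropyl in place of hydrogen on an aromatic nitrogen. Within the data shown here, no pair of measured compounds shows this kind of change, so the expectation is loose, and a moderate move toward weaker inhibition in this assay seems most likely. The expected change is a 2.7-fold higher number from compound 2 to compound 3 (0.43 log units; beyond the scatter). For compound 3, the estimated value is 300 nM, with an expected range of 70 nM to 1500 nM.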

Compound 3, half-maximal inhibitory concentration: 1600 nM
For compound 3 the middle estimate is 5.3-fold (0.73 log units) below the measured one, and the stated range ends below it.
By their numbers in this assay, from the lowest: compound 1; then compound 2; then compound 3.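

In this assay, isopropyl in place of hydrogen on the aromatic nitrogen gives a 14-fold higher number from compound 2 to compound 3 (1.15 log units; beyond the scatter) and so a much weaker inhibitor. Among these compounds, this is the first sign that the position is sensitive: the hydrogen on this nitrogen cannot be swapped for isopropyl without a large loss. Nothing available explains why the loss is so large.

Going by these compounds, whether methyl on this nitrogen would cost as much remains open, as does the effect of a longer chain ending in an amine. On these data alone, it is also open whether isopropyl on the nitrogen of compound 1 would bring a similar loss.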